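Trading a methylcarbamoyl for a tetrazole at low pH

The compounds below may be only part of what the source reports. "The series", "measured", "known", "first", "only" and "open" are said of these compounds alone.

Of the compounds shown here, three with a shared core have been measured in a physicochemical assay for solubility, with a stated time of 12 h, at pH 1.2, tested at 10 mM; a lower number here means a less soluble compound, a higher number a more soluble compound. Compound 1 `COC(=O)c1ccc(CNC(=O)c2ccc(Cl)s2)c(NC(=O)c2nc3c(s2)CN(C)CC3)c1` gives 890 ug/mL, compound 2 `CN1CCc2nc(C(=O)Nc3cc(C(=O)NS(C)(=O)=O)ccc3CNC(=O)c3ccc(Cl)s3)sc2C1` gives 990 ug/mL and compound 3 `CNC(=O)c1ccc(CNC(=O)c2ccc(Cl)s2)c(NC(=O)c2nc3c(s2)CN(C)CC3)c1` gives 140 ug/mL, the lowest number of the three. The next structure, compound 4 `CN1CCc2nc(C(=O)Nc3cc(-c4nnn[nH]4)ccc3CNC(=O)c3ccc(Cl)s3)sc2C1`, has 1H-tetrazol-5-yl in place of the methylcarbamoyl of compound 3 on an aromatic carbon: 1H-tetrazol-5-yl in place of methylcarbamoyl on an aromatic carbon.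

The measured steps all concern this same place. They show a 6.4-fold lower number from compound 1 to compound 3 (0.80 log units; beyond the scatter) and a 7.1-fold lower number from compound 2 to compound 3 (0.85 log units; beyond the scatter), so the two other groups tried there both stand well above the methylcarbamoyl. The two of them differ little, with a 1.1-fold higher number from compound 1 to compound 2 (0.05 log units; within the scatter). No tetrazole has been measured yet, so these steps suggest a direction more firmly than a size. A rise is expected, probably smaller than the gaps seen so far. In this assay the expected change is a 3.2-fold higher number from compound 3 to compound 4 (0.51 log units; beyond the scatter). For compound 4 the estimated value is 450 ug/mL, with an expected range from 130 ug/mL to 1400 ug/mL.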

Compound 4, solubility: 320 ug/mL
Compound 4: middle estimate off by 1.4-fold (0.15 log units), on the high side, within the range that was stated.
By their numbers in this assay, from the lowest: compound 3; then compound 4; then compounds 1 and 2 (each within the scatter of the next).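

In this assay the tetrazole opens a middle level at this position, on an aromatic carbon para to the (((5-chlorothiophen-2-yl)carbonyl)amino)methyl group: there is a 2.3-fold higher number from compound 3 to compound 4 (0.36 log units; beyond the scatter) and also a 2.8-fold lower number from compound 1 to compound 4 (0.44 log units; beyond the scatter) as well as a 3.1-fold lower number from compound 2 to compound 4 (0.49 log units; beyond the scatter) in the same comparison. The four groups therefore fall on three levels, with methylcarbamoyl lowest, 1H-tetrazol-5-yl in the middle, and methoxycarbonyl and (methylsulfonyl)carbamoyl together at the top, within the scatter of each other. No measurement shown here explains this order.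

From the compounds shown here alone, whether a carboxylic acid or a dimethylaminomethyl group at this position would reach the top level remains open. So does whether the same order would hold at a pH other than the one used here.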